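This account rests on a few compounds, and the source may have more. Where it says the series, first, only, none or still open, it means among the compounds named here.

Measured in an ADME assay on L6 cells (Rattus norvegicus) for cytotoxicity, read by fluorescence and resazurin assay, with a stated time of 72 h; a higher number here means that more compound is tolerated, a lower number that less compound is tolerated:
Compound 1 `CCc1ccc(-c2c[nH]cc2C(c2ccc(Cl)cc2Cl)n2ccnc2)cc1`: 13400 nM
Compound 2 `Clc1ccc(C(c2c[nH]cc2-c2ccc(Cl)cc2-c2cccs2)n2ccnc2)c(Cl)c1`: 4930 nM

Of these two compounds, compound 1 stands highest at 13400 nM, and the gap down to compound 2 at 4930 nM lies beyond the scatter. Compound 3 `CSc1ccc(-c2c[nH]cc2C(c2ccc(Cl)cc2Cl)n2ccnc2)cc1` has not yet been measured. It differs from compound 1 at a single place, with methylsulfanyl in place of ethyl on an aromatic carbon, para to a large group: methylsulfanyl in place of ethyl on an aromatic carbon. Within the data shown here, no measured pair of compounds differs in one place only, so nothing shows directly what such a change does in this assay. A small step is expected, probably none beyond the scatter, with a slight lean towards a lower number, as compound 1 at 13400 nM is the higher of the two values. The expected change is a 1.3-fold lower number from compound 1 to compound 3 (0.13 log units; within the scatter). For compound 3 the estimate is 10000 nM, with an expected range of 4500 nM to 22000 nM.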

Compound 3, half-maximal cytotoxic concentration: 7220 nM
For compound 3 the middle estimate is 1.4-fold (0.14 log units) above the measured one; the range from low to high includes it.
By their numbers in this assay, from the lowest: compounds 2, 3 and 1 (each within the scatter of the next, the first and the last beyond it).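

In this assay, putting methylsulfanyl in place of ethyl on an aromatic carbon, para to a large group, gives a 1.9-fold lower number from compound 1 to compound 3 (0.27 log units; within the scatter), the only comparison among these compounds that isolates a change in one place. At this position, the exchange of two heavy atoms for two heavy atoms, one of them now sulfur, therefore gives a step that cannot be told apart from the usual scatter of repeated measurements. No measurement shown here bears on what lies behind this small step.

Going by these compounds, whether other groups at this position, such as a methoxy group, a chlorine atom, an amine, a carboxylic acid or a longer chain, would move the number beyond the scatter stays open. Compound 2 differs from compound 1 in more than one place, so it cannot answer that question.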